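Formyl to Dimethylaminomethyl on the Aryl Ring

The source may hold more compounds than are shown below. What is called first, only, known or untested is meant among the compounds shown, and "the series" means these compounds.

Going by the values given here, compound 2 `CN1CCN(CCCN(c2nc3cc(Cl)c(Cl)cc3[nH]2)[C@@H]2CC[C@]3(c4cccc(C=O)c4)C[C@@H]3C2)CC1` gives 13.7 nM in an assay on isolated protein for binding affinity to melanin-concentrating hormone receptor 1 (Homo sapiens) (on this read-out higher numbers stand for weaker inhibition and lower numbers for stronger inhibition), the higher of the two numbers measured so far; compound 1 `CN1CCN(CCCN(c2nc3cc(Cl)c(Cl)cc3[nH]2)[C@@H]2CC[C@]3(c4cccc(C#N)c4)C[C@@H]3C2)CC1` gives 2.2 nM in this assay. Among the compounds with values here, the single measured step, a 6.2-fold higher number from compound 1 to compound 2 (0.79 log units; beyond the scatter), concerns a different exchange on the same aromatic carbon. Compound 3 `CN(C)Cc1cccc([C@]23CC[C@@H](N(CCCN4CCN(C)CC4)c4nc5cc(Cl)c(Cl)cc5[nH]4)C[C@H]2C3)c1` carries (dimethylamino)methyl in place of formyl on an aromatic carbon. Within the data shown here, no measured step involves (dimethylamino)methyl, so the direction is open, and only a modest step is expected: a 1.4-fold lower number from compound 2 to compound 3 (0.14 log units; within the scatter). Compound 3 is therefore expected to give about 10 nM in this assay, with a range from 2.5 nM to 40 nM.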

Compound 3, inhibition constant: 4.9 nM
Compound 3: middle estimate off by 2.0-fold (0.31 log units), on the high side; the measured number falls inside the stated range.
By their numbers in this assay, from the lowest: compound 1; then compound 3; then compound 2.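

In this assay the change from formyl to (dimethylamino)methyl gives a 2.8-fold lower number from compound 2 to compound 3 (0.45 log units; beyond the scatter) while the change from nitrile gives a 2.2-fold higher number from compound 1 to compound 3 (0.35 log units; beyond the scatter) at the same aromatic carbon, so compound 1 keeps the lowest number of the three. This position therefore accepts a larger group carrying a nitrogen, and the order here runs nitrile, (dimethylamino)methyl, formyl. No measurement at hand explains that order. On these data alone, whether the nitrogen itself matters stays open: a primary aminomethyl, a hydroxymethyl or a longer aminoalkyl chain on this carbon would help separate the nitrogen from the size of the group.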